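The source may report more compounds than this note shows. Statements on the series, on what has been measured and on what is new or still open speak of the compounds shown alone.

Compounds measured so far:
compound 1 `CC(=O)OC/C(=C\c1ccc([N+](=O)[O-])cc1)C(=O)c1ccccc1` — 26000 nM
compound 2 `C=C(C/C(=C\c1ccc(Cl)cc1)C(=O)c1ccccc1)C(=O)c1ccccc1` — 22000 nM
compound 3 `C=C(C/C(=C\c1ccc(F)cc1)C(=O)c1ccccc1)C(=O)c1ccccc1` — 18000 nM

All three were tested in a functional assay on HeLa cells (Homo sapiens) for inhibition, read by sulforhodamine B assay, with a stated time of 48 h; on this read-out lower numbers stand for stronger inhibition of growth and higher numbers for weaker inhibition of growth. Compound 3 gives the lowest of the three numbers, but its nearest neighbour, compound 2, stands within the scatter of it, and so does compound 1, so no order among the three can be read from these values. For the measured compounds named here, the one step in which two compounds differ in a single place, a 1.2-fold lower number from compound 2 to compound 3 (0.09 log units; within the scatter), is itself within the scatter.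

Compound 4 `C=C(C/C(=C\c1ccc(OC)cc1)C(=O)c1ccccc1)C(=O)c1ccccc1` follows from compound 3 by methoxy in place of fluoro on an aromatic carbon. Going by the values given here, no measured step involves a methoxy group, so none bears directly on this change. Among the compounds with values here, the only step available, from chloro to fluoro, was within the scatter, and the three measured compounds as a whole span a narrow range in this assay. On that basis, a change at the same aromatic carbon is expected to give no step beyond the scatter.

Compound 4 is therefore estimated at 20000 nM, with a range from 8000 nM to 50000 nM, which is expected to mean a step of a 1.1-fold higher number from compound 3 to compound 4 (0.05 log units; within the scatter).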

Compound 4, concentration for 50% growth inhibition: 320 nM
Estimate against measurement, compound 4: 63-fold (1.80 log units) above, and the stated range ends above it.
By their numbers in this assay, from the lowest: compound 4; then compounds 3, 2 and 1 (each within the scatter of the next).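

For the compounds shown here, the place on the aromatic ring para to a large group had seemed indifferent to its substituent, since the only earlier exchange there, chloro to fluoro, gave (a 1.2-fold lower number from compound 2 to compound 3 (0.09 log units; within the scatter)) in this assay. Methoxy shows that this place can in fact strongly affect the read-out: the exchange for fluoro gives (a 56-fold lower number from compound 3 to compound 4 (1.75 log units; beyond the scatter)), and the exchange for chloro gives (a 69-fold lower number from compound 2 to compound 4 (1.84 log units; beyond the scatter)), so the two halogens do not mark the limit of what this position allows. Nothing available explains why 4-methoxyphenyl differs so sharply from 4-fluorophenyl and from the chloro analogue.

The compounds shown leave open whether the gain is specific to methoxy or extends to other groups at this place, such as a hydroxyl, an ethoxy or a dimethylamino group, and whether methoxy would have the same effect at another carbon of the ring. They also leave open whether the exchange carries over to the core of compound 1, which differs from compound 4 in more than one place and so cannot be compared with it directly.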